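A few compounds are considered here, and "the series" means these few. Any claim that something is new, unique, unknown or untested is made for them only; others in the source may bear on it.

Of the compounds shown here, three sharing one core have been measured in a functional assay on MDA-MB-231 cells (Homo sapiens) for antiproliferative activity, read by MTT assay, with a stated time of 72 h; a higher number here means a weaker inhibitor, a lower number a stronger inhibitor. Compound 1 (`CC1=CC[C@H]2[C@H](CC[C@]2(C)O)C(C)(C)[C@@H]1CC[C@H]1[C@]2(C)CC[C@H](OC(=O)NS(=O)(=O)c3ccc(C)cc3)C(C)(C)O[C@H]2CC[C@@]1(C)O`), with ((4-methylphenyl)sulfonyl)amino on the carbonyl carbon, gives 47100 nM. Compound 2 (`CC1=CC[C@H]2[C@H](CC[C@]2(C)O)C(C)(C)[C@@H]1CC[C@H]1[C@]2(C)CC[C@H](OC(=O)c3ccc(Cl)c(Cl)c3)C(C)(C)O[C@H]2CC[C@@]1(C)O`), with 3,4-dichlorophenyl there, gives 8100 nM. Compound 3 (`CC1=CC[C@H]2[C@H](CC[C@]2(C)O)C(C)(C)[C@@H]1CC[C@H]1[C@]2(C)CC[C@H](OC(=O)c3cccc(C(F)(F)F)c3)C(C)(C)O[C@H]2CC[C@@]1(C)O`), with 3-(trifluoromethyl)phenyl, gives 36300 nM. Compound 3 therefore stands with compound 1 at the weak end of the set, since a 1.3-fold lower number from compound 1 to compound 3 (0.11 log units; within the scatter) stays within the scatter. Compound 2 is the strongest of the three, as a 5.8-fold lower number from compound 1 to compound 2 (0.76 log units; beyond the scatter) and a 4.5-fold higher number from compound 2 to compound 3 (0.65 log units; beyond the scatter) both lie beyond it.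

Compound 4 (`CC1=CC[C@H]2[C@H](CC[C@]2(C)O)C(C)(C)[C@@H]1CC[C@H]1[C@]2(C)CC[C@H](OC(=O)c3ccc(C(F)(F)F)c(F)c3)C(C)(C)O[C@H]2CC[C@@]1(C)O`) has 3-fluoro-4-(trifluoromethyl)phenyl in place of 3-(trifluoromethyl)phenyl on the carbonyl carbon: 3-fluoro-4-(trifluoromethyl)phenyl in place of 3-(trifluoromethyl)phenyl on a carbonyl carbon. Going by the values given here, no measured step isolates this change. The closest guide is a 4.5-fold higher number from compound 2 to compound 3 (0.65 log units; beyond the scatter), a modest step and the only one between two substituted phenyl groups. The entering group resembles the 3,4-dichlorophenyl of compound 2 in carrying two substituents on its ring, but it retains the trifluoromethyl of compound 3. A step in this assay towards a lower number is thus expected, smaller than that modest one and possibly not clear of the scatter. The estimate amounts to a 2.0-fold lower number from compound 3 to compound 4 (0.30 log units; within the scatter). Compound 4 is estimated at 18000 nM, with an expected range from 6000 nM to 50000 nM.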

Compound 4, half-maximal inhibitory concentration: 22200 nM
Beside the measured number, compound 4's estimate is 1.2-fold (0.09 log units) below it, within the range that was stated.
By their numbers in this assay, from the lowest: compound 2; then compounds 4, 3 and 1 (each within the scatter of the next, the first and the last beyond it).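

In this assay, replacing 3-(trifluoromethyl)phenyl with 3-fluoro-4-(trifluoromethyl)phenyl on the carbonyl carbon leaves compound 4 within the scatter of compound 3, a 1.6-fold lower number from compound 3 to compound 4 (0.21 log units; within the scatter), so this change to the aryl group has no clear effect on the read-out. The new compound does sharpen the picture at this place: compound 2 keeps a clear edge, a 2.7-fold higher number from compound 2 to compound 4 (0.44 log units; beyond the scatter), showing that a second ring substituent does not by itself match the 3,4-dichlorophenyl group, while compound 4 separates modestly from the sulfonyl carbamate compound 1, a 2.1-fold lower number from compound 1 to compound 4 (0.33 log units; beyond the scatter), which compound 3 did not do. No measurement bearing on these groups accompanies the result, so the steps stand without an explanation.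

With neither 4-(trifluoromethyl)phenyl nor 3-fluorophenyl among the compounds shown, the contributions of the fluorine and of the trifluoromethyl placement in compound 4 cannot be told apart. Also open, from the compounds shown here alone, is how the activity would respond to an unsubstituted phenyl, to a ring bearing an amine or a carboxylic acid, or to a longer alkyl chain on the carbonyl carbon.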